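Amide aryl substituent variation in the series

The compounds below may be only part of what the source reports. "The series", "measured", "known", "first", "only" and "open" are said of these compounds alone.

Of the compounds shown here, two have been measured so far. Compound 1 `Cc1ccc(C(=O)Nc2cccc(-c3oc4cc(-c5ccc(F)cc5)ccc4c(=O)c3O)c2)cc1` gives 6910 nM in a functional assay on A549 cells (Homo sapiens) for antiproliferative activity, read by CCK-8 assay, with a stated time of 72 h; a lower number here means a stronger inhibitor, a higher number a weaker inhibitor. Compound 2 `O=C(Nc1cccc(-c2oc3cc(-c4ccc(F)cc4)ccc3c(=O)c2O)c1)c1ccc(C(F)(F)F)cc1` gives 19400 nM in this assay. For the measured compounds named here, the single step between them, a 2.8-fold higher number from compound 1 to compound 2 (0.45 log units; beyond the scatter), is the only change with a number behind it. Going by the values given here, compound 2 thus stands at the higher of the two numbers, and compound 1 is its only neighbour.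

Compound 3 `O=C(Nc1cccc(-c2oc3cc(-c4ccc(F)cc4)ccc3c(=O)c2O)c1)c1ccc(Br)cc1` differs from compound 2 by bromo in place of trifluoromethyl on an aromatic carbon. Of the measured steps only a 2.8-fold higher number from compound 1 to compound 2 (0.45 log units; beyond the scatter) bears on this change: it concerns the same aromatic carbon and shows that an exchange of the group there moves the number by a modest amount, with trifluoromethyl at the weaker end. Among the compounds with values here, no step involving a bromo group has been measured, so the direction rests on this one comparison alone. Compound 3 is therefore expected to come out somewhat lower than compound 2, a step estimated at a 1.8-fold lower number from compound 2 to compound 3 (0.25 log units; within the scatter), though a result within the scatter would not be surprising. The estimate for compound 3 in this assay is 11000 nM, with a range from 4500 nM to 27000 nM.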

Compound 3, half-maximal inhibitory concentration: 13500 nM
Compound 3: the middle estimate sits 1.2-fold (0.09 log units) below what was measured; the measured number falls inside the stated range.
By their numbers in this assay, from the lowest: compounds 1, 3 and 2 (each within the scatter of the next, the first and the last beyond it).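

In this assay, the exchange at this aromatic carbon, para to a large group, gives a 1.4-fold lower number from compound 2 to compound 3 (0.16 log units; within the scatter), so the result does not separate bromo from trifluoromethyl here. The other comparison gives a 2.0-fold higher number from compound 1 to compound 3 (0.29 log units; within the scatter), so bromo is not separated from methyl either, and it falls in the interval between the two groups already compared. For the compounds shown here, of the three groups at this place, only methyl and trifluoromethyl remain apart, with a 2.8-fold higher number from compound 1 to compound 2 (0.45 log units; beyond the scatter) as the one step beyond the scatter, and three compounds are too few to support an ordering of substituents at this carbon. No measurement of any property of these groups accompanies the numbers, and nothing is available to explain the result.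

Going by these compounds, it remains open whether an amine, a carboxylic acid or a longer alkyl chain in place of these groups would move the number further than the steps seen so far, in either direction. On these data alone, it is also open whether the small differences among methyl, bromo and trifluoromethyl would hold up with changes elsewhere on the shared core.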